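The source may hold more compounds than are shown below. What is called first, only, known or untested is meant among the compounds shown, and "the series" means these compounds.

Of the compounds shown here, three of one series have been tested in a functional assay on PC-3 cells (Homo sapiens) for cytotoxicity, read by MTT assay, with a stated time of 72 h; a lower number here means a stronger inhibitor, a higher number a weaker inhibitor. Compound 1 `Cn1ccc2c(Oc3ccc(NC(=O)c4nn(-c5ccc(Cl)c(F)c5)ccc4=O)cc3)ccnc21` gives 32700 nM. Compound 2 `Cc1cc(=O)n(-c2ccc(F)cc2)nc1C(=O)Nc1ccc(Oc2ncnc3[nH]ccc23)cc1` reaches only a limit of the assay, > 60000 nM. Compound 3 `Cc1cc(=O)n(-c2ccc(F)cc2)nc1C(=O)Nc1ccc(Oc2ncnc3[nH]ccc23)c(F)c1` gives 17300 nM, the lowest of the two plain numbers seen so far, though compound 1 sits within the usual scatter of it. Among the measured compounds shown here, the single step between measured neighbours, an at least 3.4-fold lower number from compound 2 to compound 3 (0.54 log units; beyond the scatter), exchanges a hydrogen for a fluoro on an aromatic carbon. Compound 4 `Cc1cc(=O)n(-c2ccccc2OC(F)(F)F)nc1C(=O)Nc1ccc(Oc2ncnc3[nH]ccc23)c(F)c1` differs from compound 3 at another place: 2-(trifluoromethoxy)phenyl in place of 4-fluorophenyl on an aromatic nitrogen. For the measured compounds named here, no measured step touches this part of the molecule, so the step from compound 2 to compound 3 gives no guide to size or direction here, and the one limit recorded, (the limit of > 60000 nM in this assay, at which 1 of the 3 values shown sits), shows only how high a weak compound can sit. With nothing bearing on the change, a step no larger than the scatter is expected, a 1.0-fold lower number from compound 3 to compound 4 (0.01 log units; within the scatter). Compound 4 is therefore estimated at 17000 nM, with a range from 5000 nM to 60000 nM.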

Compound 4, half-maximal inhibitory concentration: > 60000 nM
Compound 4: a limit, no number (the forecaster's own chance of this, stated with the estimate: 25%); at least 3.5-fold (0.54 log units) between middle value and limit.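

In this assay, the aromatic nitrogen is not a neutral position: 2-(trifluoromethoxy)phenyl in place of 4-fluorophenyl gives an at least 3.4-fold higher number from compound 3 to compound 4 (0.54 log units; beyond the scatter), a change in the weaker direction. The fluoro that separates compound 3 from compound 2 is still present in compound 4, yet it does not keep the number low once this group changes. Going by these compounds, the result for compound 4 is a limit, not a number, so the full size of the step remains unknown: the limit of > 60000 nM in this assay, at which 2 of the 4 values shown sit.

The step changes both the substituent and where it sits on the phenyl ring, so the compounds shown cannot separate these two changes. On these data alone, how a plain phenyl, or a phenyl bearing an amine or a carboxylic acid, would behave on this nitrogen also remains open.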